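Same Atoms, Joined Differently: From Compound 1 to Compound 3

A few compounds are considered here, and "the series" means these few. Any claim that something is new, unique, unknown or untested is made for them only; others in the source may bear on it.

For the measured compounds named here, in a functional assay on SK-N-SH cells (Homo sapiens) for cytotoxicity, read by MTT assay, with a stated time of 48 h (on this read-out lower numbers stand for stronger inhibition and higher numbers for weaker inhibition), compound 1 (`COc1ccc(/C=C/c2cc(OC)c(OC)c(OC)c2-c2ccc3ccccc3c2)cc1`) gives 16000 nM, the lower of the two numbers measured so far, while compound 2 (`COc1ccc(/C=C/c2cc(OC)c(OC)c(OC)c2-c2ccc(OC)c(OC)c2)cc1`) gives 42000 nM. Going by the values given here, the only measured step, a 2.6-fold higher number from compound 1 to compound 2 (0.42 log units; beyond the scatter), is modest and puts 3,4-dimethoxyphenyl in place of naphthalen-2-yl, which is not the group at issue here. Compound 3 (`C=C(c1ccc(OC)cc1)c1cc(OC)c(OC)c(OC)c1-c1ccc2ccccc2c1`) has the same atoms as compound 1, joined differently: 1-(4-methoxyphenyl)ethenyl in place of 2-(4-methoxyphenyl)ethenyl on an aromatic carbon. Among the compounds with values here, no measured step touches the 2-(4-methoxyphenyl)ethenyl group, so the numbers offer no direction for this change, and no step beyond the scatter is expected, though this expectation is loose. The expected step is a 1.1-fold higher number from compound 1 to compound 3 (0.05 log units; within the scatter). In this assay, the estimated value for compound 3 is 18000 nM, with an expected range from 6000 nM to 50000 nM.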

Compound 3, half-maximal inhibitory concentration: 6000 nM
Estimate against measurement, compound 3: 3.0-fold (0.48 log units) above; the range from low to high includes it.
By their numbers in this assay, from the lowest: compound 3; then compound 1; then compound 2.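

Swapping 2-(4-methoxyphenyl)ethenyl for 1-(4-methoxyphenyl)ethenyl in this assay gives a 2.7-fold lower number from compound 1 to compound 3 (0.43 log units; beyond the scatter), with no atom gained or lost. For the compounds shown here, the earlier step changed only the naphthalen-2-yl group, so this is the first sign that the number also responds to how the 4-methoxyphenyl group and its double bond are joined to the core. Nothing measured here accounts for the shift.

On these data alone, it remains open whether the same change would also lower the number when 3,4-dimethoxyphenyl replaces naphthalen-2-yl, as in compound 2. Also open, as far as these compounds go, is whether the double bond itself matters, which a saturated 1-(4-methoxyphenyl)ethyl group would test, and how an amine or a carboxylic acid on the 4-methoxyphenyl ring in place of the methoxy group would read.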